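Aryl substituent replacement and half-life in buffer

This account rests on a few compounds, and the source may have more. Where it says the series, first, only, none or still open, it means among the compounds named here.

Measured compounds:
compound 1 `CC(=O)N[C@@H](C)C(=O)N(C)/N=N/c1ccc(Br)cc1`: 25.5 h
compound 2 `CC(=O)N[C@@H](C)C(=O)N(C)/N=N/c1ccc(C(N)=O)cc1`: 18.4 h
compound 3 `CC(=O)N[C@@H](C)C(=O)N(C)/N=N/c1ccc(C#N)cc1`: 9.8 h

In a physicochemical assay for metabolic stability, read by HPLC, in phosphate buffer, at pH 7.7 (a higher number here means that the compound lasts longer, a lower number that the compound disappears faster), compound 3 stands at the lowest of the three numbers, though a 1.9-fold lower number from compound 2 to compound 3 (0.27 log units; within the scatter) lies within the scatter and only a 2.6-fold lower number from compound 1 to compound 3 (0.42 log units; beyond the scatter) lies beyond it. Compound 4 `CC(=O)N[C@@H](C)C(=O)N(C)/N=N/c1ccc(C)cc1` differs from compound 3 by methyl in place of cyano on an aromatic carbon. Within the data shown here, no measured step involves a methyl; the steps that bear on a swap of the group on this aromatic carbon are a 1.4-fold lower number from compound 1 to compound 2 (0.14 log units; within the scatter), a 2.6-fold lower number from compound 1 to compound 3 (0.42 log units; beyond the scatter) and a 1.9-fold lower number from compound 2 to compound 3 (0.27 log units; within the scatter), which run from within the scatter to modest. A return upward is therefore expected for compound 4, of roughly a 2.0-fold higher number from compound 3 to compound 4 (0.31 log units; beyond the scatter). The estimate for compound 4 is 20 h, with a range from 10 h to 40 h.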

Compound 4, half-life: 46.5 h
Compound 4: middle estimate off by 2.3-fold (0.37 log units), on the low side; measured number above the stated range.
By their numbers in this assay, from the lowest: compounds 3, 2, 1 and 4 (each within the scatter of the next, the first and the last beyond it).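

The step of a 4.7-fold higher number from compound 3 to compound 4 (0.68 log units; beyond the scatter) and the step of a 2.5-fold higher number from compound 2 to compound 4 (0.40 log units; beyond the scatter) show that a swap on this aromatic carbon can move the half-life further than the bromo, carbamoyl and cyano compounds alone indicated. The step of a 1.8-fold higher number from compound 1 to compound 4 (0.26 log units; within the scatter) gives no order between methyl and bromo. Nothing available explains these differences in half-life.

Open, going by these compounds, is where an amine, a methoxy group or a carboxylic acid on this carbon would fall. Also open, on these data alone, is whether a longer chain in place of methyl would keep the half-life of compound 4.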